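This account rests on a few compounds, and the source may have more. Where it says the series, first, only, none or still open, it means among the compounds named here.

Measured in a functional assay on U-373MG ATCC cells (Homo sapiens) for inhibition, read by colorimetric assay and MTT assay, with a stated time of 72 h; on this read-out lower numbers stand for stronger inhibition and higher numbers for weaker inhibition:
- compound 1 `C=CCCCCOc1ccccc1-c1cnc(OCCCCC=C)n1C` gives 7000 nM
- compound 2 `C=CCCCCCOc1ncc(-c2ccccc2OCCCCC=C)n1C` gives 76000 nM
- compound 3 `COc1ccccc1-c1cnc(OC)n1C` gives > 100000 nM, which is a limit and not a number

Compound 3 therefore has no exact place on the scale, only this limit. Compound 4 `C=CCCCCOc1ccccc1-c1cnc(OC)n1C` differs from it by one change: pent-4-en-1-yl in place of hydrogen on a saturated chain carbon bound to an oxygen on an aromatic ring. In other words, one methoxy becomes (hex-5-en-1-yl)oxy, while the other methoxy stays.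

Within the data shown here, no measured step matches this change directly. The nearest is an 11-fold higher number from compound 1 to compound 2 (1.04 log units; beyond the scatter), a large step that lengthens one such chain and shows that the two chain-bearing compounds differ clearly. With (hex-5-en-1-yl)oxy in place of each methoxy, compound 1 gives 7000 nM. Compound 4 gains only one of these chains, so a move toward a lower number is expected, though probably a modest one that may stay close to the limit.

The expected change is an at least 2.8-fold lower number from compound 3 to compound 4 (0.45 log units; beyond the scatter). For compound 4 the estimated value is 35000 nM, with an expected range of 10000 nM to 100000 nM.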

Compound 4, half-maximal inhibitory concentration: > 100000 nM
Compound 4: a limit, no number; the forecaster's own chance of this, stated with the estimate: 25%; at least 2.8-fold (0.45 log units) between middle value and limit.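

In this assay compound 4 gives > 100000 nM, which is a limit and not a number, so a single (hex-5-en-1-yl)oxy in place of methoxy does not bring the compound onto the measurable scale. The second chain of compound 1 therefore matters, with an at least 14-fold higher number from compound 1 to compound 4 (1.15 log units; beyond the scatter), whereas the comparison with the longer-chain compound is less informative, with an at least 1.3-fold higher number from compound 2 to compound 4 (0.11 log units; that floor lies within the scatter). The step from compound 3 to compound 4 cannot be read, since both compounds sit at the same limit: the limit of > 100000 nM in this assay, at which 2 of the 4 values shown sit.

Going by these compounds, it stays open whether the chain on the other oxygen alone, with the methoxy kept on the aromatic ring, would give a number. Among these compounds, it also stays open whether an amine or a carboxylic acid at the end of the single chain would change the reading.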